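The source may report more compounds than this note shows. Statements on the series, on what has been measured and on what is new or still open speak of the compounds shown alone.

Of the compounds shown here, three that share one core have been measured in an assay (Rattus norvegicus) for inhibition of Fatty-acid amide hydrolase 1 (Homo sapiens); on this read-out lower numbers stand for stronger inhibition and higher numbers for weaker inhibition. Compound 2 `Cc1cccc(-c2cnc(C(=O)CCCCCCc3ccccc3)o2)n1` gives 3.3 nM, the lowest number of the three. Compound 3 `COC(=O)c1ccc(-c2cnc(C(=O)CCCCCCc3ccccc3)o2)nc1` gives 3.5 nM, which lies within the usual scatter of the value of compound 2, so the two cannot be ranked. Compound 1 `COC(=O)c1ccc(-c2cnc(C(=O)CCCCCCc3ccccc3)o2)cc1` gives 40 nM, a number higher than that of compound 2 by more than the scatter, so compound 1 inhibits less strongly. Compound 4 `O=C(CCCCCCc1ccccc1)c1ncc(-c2cc(=O)[nH]c(=O)[nH]2)o1` has not been measured; it differs from compound 2 by a group of 8 heavy atoms (4 carbon, 2 nitrogen, 2 oxygen; one six-membered aromatic ring with 2 hetero atoms) in place of a group of 7 heavy atoms (6 carbon, 1 nitrogen; one six-membered aromatic ring with 1 hetero atom), on an aromatic carbon. Because compound 1 gives 40 nM with a different ring in this place, a change here can weaken inhibition. The expected step is a 6.1-fold higher number from compound 2 to compound 4 (0.78 log units; beyond the scatter), a loss somewhat beyond the scatter. Compound 4 is expected to give about 20 nM, between 3 nM and 150 nM.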

Compound 4, inhibition constant: 12 nM
The estimate for compound 4 lay 1.7-fold (0.22 log units) above the measured number; the range from low to high includes it.
By their numbers in this assay, from the lowest: compounds 2 and 3 (each within the scatter of the next); then compound 4; then compound 1.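

Replacing the 6-methylpyridin-2-yl group with a six-membered aromatic ring with 2 hetero atoms, bearing 2 hydrogen-bond donors, gives a 3.6-fold higher number from compound 2 to compound 4 (0.56 log units; beyond the scatter). This place on the five-membered ring therefore accepts a group with hydrogen-bond donors, at a modest cost, and compound 4 still gives 12 nM. Nothing measured here explains the loss.

Ring atoms, the methyl group and the donors all change in this one step, and the compounds shown cannot separate them. Going by these compounds, it remains open how an unsubstituted pyridin-2-yl group or a ring bearing a carboxylic acid would behave at this place.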